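The source may hold more compounds than are shown below. What is called first, only, known or untested is meant among the compounds shown, and "the series" means these compounds.

Measured so far:
compound 1 `Nc1nc(NCc2ccc(F)cc2)nc(-c2ccccc2CO)n1` — 3.97
compound 2 `Nc1nc(NCc2ccc(C(F)(F)F)cc2)nc(-c2ccccc2CO)n1` — 5.03

Both numbers come from a functional assay on cells for positive allosteric modulation of G-protein coupled receptor 68 (Homo sapiens), read by a luciferase reporter and cAMP accumulation, with a stated time of 30 min, at pH 6.8 and pH 8.3, in the presence of a further agent that is not named here; a higher number here means a more potent compound, by a factor of ten per unit of this negative logarithm, a lower number a less potent compound. Among the measured compounds shown here, compound 1 stands lowest of the two; its only neighbour is compound 2, and a number 1.06 log units higher from compound 1 to compound 2 (beyond the scatter) gives that gap, beyond the scatter, for trifluoromethyl in place of fluoro on an aromatic carbon.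

Compound 3 `Cc1ccccc1CNc1nc(N)nc(-c2ccccc2CO)n1` has not been measured. Against compound 1 the change is 2-methylphenyl in place of 4-fluorophenyl on a saturated chain carbon bound to a nitrogen on an aromatic ring. For the measured compounds named here, no measured step covers this exchange. Going by the values given here, the one known step, from compound 1 to compound 2, keeps a substituent on the same aromatic carbon and only swaps fluoro for trifluoromethyl; it shows that the substituent on this ring can move this assay strongly, but it says nothing about a 2-methylphenyl with the fluorine gone. The direction therefore cannot be read from compound 2, and the expectation rests on compound 1 alone with a wide range. For compound 3 the expected step is a number 0.23 log units higher from compound 1 to compound 3 (within the scatter), which may fall within the scatter. Compound 3 is estimated at 4.2, between 3.5 and 5.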

Compound 3, negative logarithm of the antagonist equilibrium constant: 4.7
Compound 3: middle estimate off by 0.50 log units, on the low side; measured number inside the range.
By their numbers in this assay, from the lowest: compound 1; then compound 3; then compound 2.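

In this assay, 2-methylphenyl in place of 4-fluorophenyl on the saturated chain carbon gives a number 0.73 log units higher from compound 1 to compound 3 (beyond the scatter), so a rise in this number at this position does not depend on keeping a substituent on the aromatic carbon that carries fluoro in compound 1 or trifluoromethyl in compound 2. Compound 3 carries no fluorine at all, while the leaving and entering groups both count 7 heavy atoms, 0 hydrogen-bond donors and 0 hydrogen-bond acceptors, so these counts do not tell the two groups apart. Nothing available bears on what lies behind this step.

From the compounds shown here alone, the change from compound 1 to compound 3 removes fluoro and introduces methyl in one exchange, and what 4-methylphenyl or 2-fluorophenyl would give remains open, leaving the two parts of the change unseparated. Also open, going by these compounds, is how an amine or a carboxylic acid on this phenyl ring, a longer chain in place of the saturated chain carbon, or methyl and trifluoromethyl together on one ring would read in this assay.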